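Fluoro for hydrogen on the aryl ring of compound 1

The source may report more compounds than this note shows. Statements on the series, on what has been measured and on what is new or still open speak of the compounds shown alone.

Measured so far:
Compound 1, `CC(C(=O)N1CCN(c2ccccc2)CC1)N1C(=O)CCC1=O`, gives 50% in a functional assay on the whole organism (strain Swiss) with Mus musculus as the target, in the maximal electroshock model, with a stated time of 0.5 h, at a dose of 300 mg/kg by the intraperitoneal route; on this read-out lower numbers stand for a weaker effect and higher numbers for a stronger effect at the one dose given.
Compound 2, `CCC(C(=O)N1CCN(c2ccc(C(F)(F)F)cc2)CC1)N1C(=O)CCC1=O`, gives 0% in this assay.

Compound 1 stands highest of the two numbers measured. Among the compounds with values here, its nearest neighbour is compound 2, whose number is lower by a gap that lies beyond the usual scatter; compound 2 also differs from compound 1 in more than one place, so no single step between the two can be drawn.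

The unmeasured compound 3, `CC(C(=O)N1CCN(c2ccc(F)cc2)CC1)N1C(=O)CCC1=O`, keeps the core of compound 1 and differs from it in one place: fluoro in place of hydrogen on an aromatic carbon. The fluorine sits on the six-membered aromatic ring of carbon only, para to a large group, so that phenyl becomes 4-fluorophenyl.

Within the data shown here, no measured step of this kind is available, so the expectation rests on compound 1 alone. A fluoro group entering for a hydrogen is a small change, and the step of a number 10 percentage points lower from compound 1 to compound 3 (within the scatter) is expected to be small, possibly a mild weakening, and may well stay within the scatter. Compound 3 is therefore estimated to give 40% in this assay, with a range from 0% to 80%.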

Compound 3, a percentage reported as activity, at one dose (the size of the read-out at that dose, not a potency): 50%
Compound 3: the middle estimate sits 10 percentage points below what was measured, within the range that was stated.
By their numbers in this assay, from the lowest: compound 2; then compounds 1 and 3 (each within the scatter of the next).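

Fluoro in place of hydrogen on an aromatic carbon, which turns phenyl into 4-fluorophenyl, gives no change at the digits printed from compound 1 to compound 3 (within the scatter) in this assay. Within the data shown here, this is the first step that changes only one place, so it gives a first direct reading for this position on the six-membered aromatic ring: here, a fluoro group can replace the hydrogen without a change in the read-out beyond the scatter. The reading applies only to the size of the effect at the one dose given and is not a measure of potency, and no measurement on hand offers an explanation for this outcome.

On these data alone, it remains open whether a chloro group, a methoxy group or an amine at the same place would leave the read-out just as unmoved, and whether fluoro at another place on the ring would do the same. A single pair of compounds establishes no trend, and it is also unknown whether this step would read the same way on a compound with a longer chain on the shared core.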